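A few compounds are considered here, and "the series" means these few. Any claim that something is new, unique, unknown or untested is made for them only; others in the source may bear on it.

Compound 2 `COc1ccc(OCCCON2C(N)=NC(N)=NC23CCOCC3)cc1` is the starting point of this step. In an assay on isolated protein for inhibition of Dihydrofolate reductase (Homo sapiens), read by spectrophotometry, using NADPH, with stated times of 5 s and 6 min, tested at 5 uM (on this read-out lower numbers stand for a weaker effect and higher numbers for a stronger effect at the one concentration tested), compound 2 gives > 90%, which is a limit of the assay rather than a number. Its two dichlorophenyl relatives carry a different core: compound 1 `NC1=NC2(CCSCC2)N(OCCCOc2ccc(Cl)c(Cl)c2)C(N)=N1` gives 88.4% in this assay, and compound 3 `NC1=NC2(CCSCC2)N(OCCCOc2cccc(Cl)c2Cl)C(N)=N1` gives 83.8%. Among the compounds with values here, the one measured step, a number 4.6 percentage points lower from compound 1 to compound 3 (within the scatter), shows that moving chlorine around the aryl ring leaves the read-out essentially unchanged. The unmeasured compound 4 `NC1=NC2(CCOCC2)N(OCCCOc2ccc(Cl)cc2Cl)C(N)=N1` keeps the core of compound 2 and differs from it by 2,4-dichlorophenyl in place of 4-methoxyphenyl on an oxygen on a saturated carbon. Within the data shown here, no measured step bears directly on an exchange of methoxy for dichloro on this aryl ring, and both dichlorophenyl compounds measured so far sit a little under the limit at which compound 2 stands, where (the limit of > 90% in this assay, at which 1 of the 3 values shown sits). A small downward step, or none beyond the scatter, is therefore expected, and the estimate is bounded above by that limit. Compound 4 is expected to give 87% in this assay, between 72% and 90%. This estimate means an expected step of a number at least 3 percentage points lower from compound 2 to compound 4 (that floor lies within the scatter).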

Compound 4, a percentage reported as inhibition, at one concentration (the size of the read-out at that concentration, not a potency): > 90%
Compound 4: a limit, no number; the forecaster's own chance of this, stated with the estimate: 35%; middle value at least 3 percentage points away from the limit.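

In this assay compound 4 gives > 90% as a limit of the assay and not a number. Within the data shown here, compound 2 also stands at a limit, so no step between compound 2 and compound 4 can be read. The compounds shown leave open whether 2,4-dichlorophenyl in place of 4-methoxyphenyl changes the inhibition at all.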